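A few compounds are considered here, and "the series" means these few. Any claim that something is new, unique, unknown or untested is made for them only; others in the source may bear on it.

The study concerns one shared core, seen in compound 1 `C=CC1=C(C(=O)NCc2ccc(Cl)cc2)C(c2ccc(OC)c(OC)c2)OC1`, compound 2 `C=CC1=C(C(=O)Nc2ccccc2)C(c2ccc(Cl)c(Cl)c2)OC1` and compound 3 `C=CC1=C(C(=O)NCc2ccccc2)C(c2ccc(Cl)c(Cl)c2)OC1`, all tested in a functional assay on A549 cells (Homo sapiens) for cytotoxicity, read by MTT assay, with a stated time of 24 h; a lower number here means a stronger inhibitor, a higher number a weaker inhibitor. For compound 1 the assay returns only a limit, > 100000 nM. For compound 2 the result is likewise a limit, > 100000 nM. Compound 3 too comes back as a limit, > 100000 nM. Among the measured compounds shown here, the only single-point comparison among them, a step that the two limits leave unreadable from compound 2 to compound 3, is unreadable, and the limit of > 100000 nM in this assay, at which 3 of the 3 values shown sit, describes where every value so far sits.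

Compound 4 `C=CC1=C(C(=O)NCCC)C(c2ccc(Cl)c(Cl)c2)OC1` has not yet been measured in this assay. It differs from compound 3 by ethyl in place of phenyl on a saturated chain carbon bound to an amide-type nitrogen, the same difference reading, cut one bond further out, as benzyl to propyl. For the measured compounds named here, no measured step speaks to this change with a readable size; the numbers leave compound 3 at the limit with nothing to set it against. The expected outcome is therefore no step beyond the scatter, a step that the limit leaves unreadable from compound 3 to compound 4. Compound 4 is estimated at 150000 nM, within 30000 nM to 1000000 nM, and is expected most likely to be reported as a limit again.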

Compound 4, half-maximal inhibitory concentration: > 100000 nM
Compound 4 was reported as a limit (the forecaster's own chance of this, stated with the estimate: 85%); the middle value lies beyond the limit too.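

Among the compounds shown here, compound 4 gives > 100000 nM in this assay as a limit, so no step from compound 2 or compound 3 to compound 4 can be read: the limit of > 100000 nM in this assay, at which 4 of the 4 values shown sit. The compounds shown leave open whether any change to the shared core gives a measurable value in this assay at all.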